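Swapping tert-butyl for methylsulfonyl in a weak inhibitor

The source may report more compounds than this note shows. Statements on the series, on what has been measured and on what is new or still open speak of the compounds shown alone.

Compound 1 `OCc1ccc(-c2nn(Cc3ccccc3F)c3ncncc23)o1` gives 9400 nM in a functional assay (aorta) with Oryctolagus cuniculus as the target; a lower number here means a stronger inhibitor, a higher number a weaker inhibitor.
Compound 2 `Cc1oc(-c2nn(Cc3ccccc3F)c3ncccc23)nc1CO` gives 1500 nM in this assay.
Compound 3 `CC(C)(C)c1cnc(-c2nn(Cc3ccccc3F)c3ncccc23)nc1N` gives 709000 nM in this assay.

Compound 3 has the highest of the three numbers and is therefore the weakest inhibitor of the set, well apart from compound 1 and further still from compound 2. Compound 4 `CS(=O)(=O)c1cnc(-c2nn(Cc3ccccc3F)c3ncccc23)nc1N` keeps the whole of compound 3 except one group: methylsulfonyl in place of tert-butyl on an aromatic carbon. Going by the values given here, no two measured compounds differ in a single place, so no earlier step shows what such a swap does. The group that enters matches the one that leaves in size but brings hydrogen-bond acceptors where there were none. Without guidance, the step of a 1.8-fold lower number from compound 3 to compound 4 (0.25 log units; within the scatter) is expected to be small, within or near the scatter. Compound 4 is estimated at 400000 nM, ranging from 60000 nM to 2500000 nM.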

Compound 4, half-maximal inhibitory concentration: 261000 nM
Compound 4: middle estimate off by 1.5-fold (0.19 log units), on the high side; low and high end bracket the measured number.
By their numbers in this assay, from the lowest: compound 2; then compound 1; then compound 4; then compound 3.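

In this assay, methylsulfonyl in place of tert-butyl on this aromatic carbon, ortho to an amino group, gives a 2.7-fold lower number from compound 3 to compound 4 (0.43 log units; beyond the scatter) and so gives the set its first change made in a single place. The position therefore accepts a group of the same heavy-atom count that carries hydrogen-bond acceptors, with a modest gain rather than a loss. No measurement at hand accounts for the step.

Going by these compounds, whether an amine, a carboxylic acid or a longer chain on this carbon would move the number further remains open.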